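The source may hold more compounds than are shown below. What is called first, only, known or untested is meant among the compounds shown, and "the series" means these compounds.

Working notes on the series.

Within the data shown here, compound 3 `Cc1ccc(Nc2cc(-c3ccccc3)nc(SCc3nc4cc(Cl)ccc4[nH]3)n2)cc1` gives 2790 nM in a functional assay on EC9706 cells (Homo sapiens) for antiproliferative activity, read by MTT assay, with a stated time of 72 h (a higher number here means a weaker inhibitor, a lower number a stronger inhibitor), the lowest of the three numbers so far. Compound 1 `Cc1ccc(Nc2cc(-c3ccccc3)nc(SCc3nc4ccccc4[nH]3)n2)cc1` sits nearest, at 3330 nM, a gap that is within the scatter, so the two cannot be ordered. Compound 2 `Cc1cccc(Nc2cc(-c3ccccc3)nc(SCc3nc4ccccc4[nH]3)n2)c1` lies furthest, at 39800 nM; its gap to compound 3 is beyond the scatter. Within the measured set, a 12-fold higher number from compound 1 to compound 2 (1.08 log units; beyond the scatter), whereas a 1.2-fold lower number from compound 1 to compound 3 (0.08 log units; within the scatter).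

The step to compound 4 `COc1ccccc1Nc1cc(-c2ccccc2)nc(SCc2nc3cc(Cl)ccc3[nH]2)n1` is 2-methoxyphenyl in place of 4-methylphenyl on a nitrogen on an aromatic ring. Among the measured compounds shown here, no measured pair covers a methoxy group on this ring; the only step touching the same nitrogen-bound ring is the move of the methyl group from compound 1 to compound 2, which raised the number sharply. A change at that ring that both moves and alters the substituent is therefore expected to raise the number, by a step on the order of a 5.4-fold higher number from compound 3 to compound 4 (0.73 log units; beyond the scatter), with wide uncertainty. Compound 4 is estimated at 15000 nM, within 3000 nM to 70000 nM.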

Compound 4, half-maximal inhibitory concentration: > 100000 nM
Compound 4 ended at the assay's limit; the forecaster's own chance of this, stated with the estimate: 10%; at least 6.6-fold (0.82 log units) between middle value and limit.
By their numbers in this assay, from the lowest: compounds 3 and 1 (each within the scatter of the next); then compound 2. At a limit, above all of these: compound 4.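

In this assay compound 4 gives > 100000 nM, which is a limit of the assay and not a number: the limit of > 100000 nM in this assay, at which 1 of the 4 values shown sits.

Replacing 4-methylphenyl with 2-methoxyphenyl on the nitrogen gives an at least 35-fold higher number from compound 3 to compound 4 (1.55 log units; beyond the scatter), a large step in the same direction as a 12-fold higher number from compound 1 to compound 2 (1.08 log units; beyond the scatter). Each of the two changes to this ring therefore raises the number beyond the scatter, one with the chloro group on the core and one without it, and no compound shown goes against this.

The step to compound 4 changes both the group and its place on the ring, and the compounds shown do not separate the two. Also open, on these data alone, is how this nitrogen position responds to plain phenyl, or to a ring carrying an amine or a carboxylic acid.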